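A few compounds are considered here, and "the series" means these few. Any claim that something is new, unique, unknown or untested is made for them only; others in the source may bear on it.

Measured so far in a functional assay on CRL2813 cells (Homo sapiens) for cytotoxicity, read by sulforhodamine B assay, with a stated time of 5 days; a higher number here means a weaker inhibitor, a lower number a stronger inhibitor:
compound 1, `O=C(Nc1ccc([N+](=O)[O-])cc1)N[C@H]1CC[C@H](Oc2ccc(F)cc2)CC1`: 2300 nM
compound 2, `COC(=O)c1cccc(NC(=O)N[C@H]2CC[C@H](Oc3ccc(F)cc3)CC2)c1`: 9200 nM
compound 3, `O=C(Nc1cccc(C(F)(F)F)c1)N[C@H]1CCC[C@H](Oc2ccc(C(F)(F)F)cc2)C1`: 3800 nM

Compound 1 gives the lowest number of the three in this assay. Compound 3 falls within the scatter of compound 1, so no order between these two can be drawn from the numbers; compound 2 lies beyond the scatter above compound 1. Within the data shown here, no pair among the measured compounds differs in a single place, so no step of known size is available.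

Compound 4, `O=C(Nc1ccccc1Cl)N[C@H]1CC[C@H](Oc2ccc(F)cc2)CC1`, has not yet been measured in this assay. Against compound 1 the change is 2-chlorophenyl in place of 4-nitrophenyl on an amide-type nitrogen. Among the measured compounds shown here, nothing among the measured compounds shows how this kind of change on the shared core plays out, so the expectation rests on compound 1 alone and carries a wide range. A step of modest size, within or only just beyond the scatter, is expected, with no firm direction. Compound 4 is estimated at 3000 nM, with a range from 1000 nM to 10000 nM. This estimate means an expected step of a 1.3-fold higher number from compound 1 to compound 4 (0.12 log units; within the scatter).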

Compound 4, half-maximal inhibitory concentration: 9100 nM
Estimate against measurement, compound 4: 3.0-fold (0.48 log units) below, within the range that was stated.
By their numbers in this assay, from the lowest: compounds 1 and 3 (each within the scatter of the next); then compounds 4 and 2 (each within the scatter of the next).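

In this assay, the group on the amide-type nitrogen of the shared core now has a readable step: 2-chlorophenyl in place of 4-nitrophenyl gives a 4.0-fold higher number from compound 1 to compound 4 (0.60 log units; beyond the scatter), so this place is not indifferent to the group it carries. With the same core, compound 4 at 9100 nM and compound 2 at 9200 nM lie within the scatter of each other, so these two groups cannot be put in order. Nothing measured here bears on why the step arises.

Going by these compounds, whether the chlorine itself matters remains open, as a plain phenyl on the same nitrogen would be needed to separate the contributions of the two groups. Also open, on these data alone, is how an amine or a carboxylic acid on that phenyl ring would compare with the 4-nitrophenyl of compound 1.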